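The source may hold more compounds than are shown below. What is called first, only, known or untested is meant among the compounds shown, and "the series" means these compounds.

Compound 1, `COc1ccc(-n2nc(-c3ccc(O)cc3)nc2CNc2ccc(C(=O)NO)cc2)cc1`, gives 70.3% in an assay on Sf9 cells for inhibition of protein deacetylase HDAC6 (Homo sapiens), read by fluorescence, with a stated time of 40 min, tested at 100 nM; on this read-out higher numbers stand for more inhibition at the one concentration tested (going by the name of the read-out) and lower numbers for less inhibition.
Compound 2, `O=C(NO)c1ccc(NCc2nc(-c3ccccc3)nn2-c2ccc(Br)cc2)cc1`, gives 65.9% in this assay.
Compound 3, `O=C(NO)c1ccc(NCc2nc(-c3ccc(F)cc3)nn2-c2ccccc2)cc1`, gives 70.9% in this assay.

All three share the same core and differ only in the groups on the two outer benzene rings. Compound 2 lies within the scatter of compound 1 and also within the scatter of compound 3, so on these numbers none of the three can be told apart from the others; they form one cluster of similar inhibition.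

Compound 4, `CC(C)c1ccc(-n2nc(-c3ccccc3)nc2CNc2ccc(C(=O)NO)cc2)cc1`, has not yet been measured in this assay. It differs from compound 2 in one place: isopropyl in place of bromo on an aromatic carbon. Within the data shown here, no step between two measured compounds isolates a change of this kind, so nothing here shows how swapping one substituent for another on that ring moves the read-out. With the three measured compounds all within the scatter of each other, the expectation is a step of no clear size in either direction, with the estimated change from compound 2 to compound 4 being a number 0.1 percentage points higher from compound 2 to compound 4 (within the scatter). Compound 4 is therefore estimated at 66%, with a likely range from 50% to 80%.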

Compound 4, a percentage reported as inhibition, at one concentration (the size of the read-out at that concentration, not a potency): 52.6%
Beside the measured number, compound 4's estimate is 13.4 percentage points above it, and the stated range covers the measured number.
By their numbers in this assay, from the lowest: compound 4; then compounds 2, 1 and 3 (each within the scatter of the next).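

Swapping bromo for isopropyl on this ring gives a number 13.3 percentage points lower from compound 2 to compound 4 (beyond the scatter) in this assay, the only step so far that isolates a single change. So this place, para to a large group, is not indifferent to what sits on it: 4-bromophenyl and 4-isopropylphenyl can be told apart here, although the three earlier compounds could not be separated from one another. Nothing measured here says why the number falls with this swap.

Among these compounds, with only two groups compared at this place and everything else held fixed, one step gives no trend. On these data alone, it remains open how a methyl group, an amine or a carboxylic acid at the same place would read, and whether the same swap would give a similar step with a different group on the other outer ring.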